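The compounds below may be only part of what the source reports. "The series", "measured", "known", "first", "only" and "open" are said of these compounds alone.

Values in a functional assay for inhibition of nuclear factor NF-kappa-B complex (Homo sapiens); on this read-out lower numbers stand for stronger inhibition and higher numbers for weaker inhibition:
compound 1 `CCCC(=O)C1=Cc2ccc(OC)cc2OC1c1cc(OC)c(OC)c(OC)c1`, 11700 nM
compound 2 `COc1ccc2c(c1)OC(c1cc(OC)c(OC)c(OC)c1)C(C(=O)N(C)C)=C2`, > 50000 nM

The figure for compound 2 in this assay is a limit of the assay, not a measured number, as shown by the limit of > 50000 nM in this assay, at which 1 of the 2 values shown sits. Among the compounds with values here, the one measured step, an at least 4.2-fold higher number from compound 1 to compound 2 (0.63 log units; beyond the scatter), already ends at that limit. Compound 3 `COc1ccc2c(c1)OC(c1cc(OC)c(OC)c(OC)c1)C(C(=O)NC(C)(C)C)=C2` differs from compound 2 by (tert-butyl)amino in place of dimethylamino on a carbonyl carbon. Within the data shown here, no measured step covers this change; the single step measured concerns a different exchange at the same carbonyl carbon and gives no direction for it. Compound 3 is thus expected to stay near the limit, an expected step that the limit leaves unreadable from compound 2 to compound 3. The estimate for compound 3 is 60000 nM, between 20000 nM and 150000 nM.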

Compound 3, half-maximal inhibitory concentration: 28400 nM
Estimate against measurement, compound 3: 2.1-fold (0.32 log units) above, within the range that was stated.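

In this assay, from the compounds shown here alone, (tert-butyl)amino in place of dimethylamino on this carbonyl carbon gives an at least 1.7-fold lower number from compound 2 to compound 3 (0.24 log units; that floor lies within the scatter) and so shows that an amide here can return a measured number, though the size of this change stays unknown. Exchanging propyl for (tert-butyl)amino gives a 2.4-fold higher number from compound 1 to compound 3 (0.39 log units; beyond the scatter) and leaves propyl the better of these two groups. The figure for compound 2 is a limit, not a number: the limit of > 50000 nM in this assay, at which 1 of the 3 values shown sits.

Going by these compounds, how a chain longer than propyl would read on this carbonyl carbon remains open. So does the reading of methylamino or a carboxylic acid at this position.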